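The compounds below may be only part of what the source reports. "The series", "measured", "known", "first", "only" and "open" are said of these compounds alone.

Compound 1 `CCC(COc1ccccc1)OC(=O)NCc1ccccc1` is the point of departure. In an assay for inhibition of zeta-carotene desaturase, chloroplastic/chromoplastic (Capsicum annuum), using a Dixon plot, with a stated time of 8 h (on this read-out higher numbers stand for weaker inhibition and lower numbers for stronger inhibition), compound 1 gives > 100000 nM, which is a limit of the assay rather than a number. Compound 2 `CCC(COc1cccc([N+](=O)[O-])c1)OC(=O)NCc1ccccc1` adds a nitro group to the aromatic ring, and in this assay compound 2 gives > 100000 nM, again a limit. Compound 3 `CCC(COc1cccc(C(C)C)c1)OC(=O)NCc1ccccc1` adds an isopropyl group, and in this assay compound 3 gives > 100000 nM, also a limit. The steps a step that the two limits leave unreadable from compound 1 to compound 2, a step that the two limits leave unreadable from compound 1 to compound 3 and a step that the two limits leave unreadable from compound 2 to compound 3 cannot be given a size because every value sits at the limit of > 100000 nM in this assay, at which 3 of the 3 values shown sit. So compound 1 stands at the edge of what this assay can report, with nothing weaker or stronger to compare it to.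

Compound 4 `CCC(COc1cccc(Cl)c1Cl)OC(=O)NCc1ccccc1` differs from compound 1 by 2,3-dichlorophenyl in place of phenyl on an oxygen on a saturated carbon. Going by the values given here, no measured step covers two chlorine atoms on that ring; the two ring changes that were measured, nitro and isopropyl, both stayed at the limit. The step of a number no higher from compound 1 to compound 4 (the limit leaves the size open) is therefore expected to be none that this assay can read. For compound 4 the estimate is 100000 nM, within a range from 30000 nM to 300000 nM, most likely reported once more as a limit.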

Compound 4, half-maximal inhibitory concentration: > 100000 nM
Compound 4 gave a limit, no number; the forecaster's own chance of this, stated with the estimate: 80%; the middle value lies on the limit itself.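

In this assay compound 4 gives > 100000 nM, a limit and not a number. The step between compound 1 and compound 4 therefore cannot be read: the limit of > 100000 nM in this assay, at which 4 of the 4 values shown sit. The compounds shown leave open which change to the shared core, if any, would give a measurable number in this assay.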